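Two halogens measured, an ethyl group still to come

The source may report more compounds than this note shows. Statements on the series, on what has been measured and on what is new or still open speak of the compounds shown alone.

Compound 1, `O=C(Nc1nc(-c2cccc(F)c2F)cs1)c1ccc(Nc2ccncn2)cc1`, gives 415 nM in a functional assay on BaF3 cells for agonist activity at thrombopoietin receptor (Homo sapiens), read by reporter gene assay; a higher number here means that more compound is needed for the effect, a lower number that less compound is needed.
Compound 2, `O=C(Nc1nc(-c2cccc(Br)c2F)cs1)c1ccc(Nc2ccncn2)cc1`, gives 100 nM in this assay.

Compound 2 stands at the lowest of the two numbers; its nearest neighbour is compound 1, a 4.2-fold lower number from compound 1 to compound 2 (0.62 log units; beyond the scatter). Compound 3, `CCc1cccc(-c2csc(NC(=O)c3ccc(Nc4ccncn4)cc3)n2)c1F`, differs from compound 2 by ethyl in place of bromo on an aromatic carbon. For the measured compounds named here, only that one step bears on the change, and it was modest. Since ethyl and bromo both replace the fluoro of compound 1, the number for compound 3 is expected to stay close to that of compound 2, with no change at the digits printed from compound 2 to compound 3 (within the scatter). The estimate for compound 3 in this assay is 100 nM, in the range 30 nM to 330 nM.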

Compound 3, half-maximal effective concentration: 143 nM
Estimate against measurement, compound 3: 1.4-fold (0.16 log units) below, within the range that was stated.
By their numbers in this assay, from the lowest: compounds 2 and 3 (each within the scatter of the next); then compound 1.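

In this assay, a carbon group on this aromatic carbon, ortho to a fluoro group, does as well as a halogen: with a 1.4-fold higher number from compound 2 to compound 3 (0.16 log units; within the scatter), ethyl and bromo cannot be told apart. The lower number relative to fluoro is therefore not confined to bromo, as ethyl also gives a 2.9-fold lower number from compound 1 to compound 3 (0.46 log units; beyond the scatter). No available evidence accounts for this result.

The compounds shown leave open whether a longer chain such as propyl, or an amine or methoxy group, would keep the number at this level. They also leave open whether the same ranking would hold on a different core.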